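Ethoxy in place of 4-fluoro-1H-pyrazol-1-yl: expectation for compound 3

The source may report more compounds than this note shows. Statements on the series, on what has been measured and on what is new or still open speak of the compounds shown alone.

Of the compounds shown here, two have been measured so far in an ADME assay on a cell-free system (serum, Bos taurus) for protein binding. There, compound 1 `Cc1cc(C(=O)NNS(=O)(=O)c2ccccc2F)cc(-n2cc(F)cn2)c1` gives 83.2% and compound 2 `CCCOc1cccc(C(=O)NNS(=O)(=O)c2ccccc2F)c1` gives 71%. These two values lie within the usual scatter of each other, so the numbers do not separate compound 1 from compound 2.

Compound 3 `CCOc1cc(C)cc(C(=O)NNS(=O)(=O)c2ccccc2F)c1` keeps the shared core and the methyl group of compound 1. It carries ethoxy in place of 4-fluoro-1H-pyrazol-1-yl on an aromatic carbon, meta to a large group and meta to a methyl group: ethoxy in place of 4-fluoro-1H-pyrazol-1-yl on an aromatic carbon.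

Within the data shown here, no measured pair isolates this replacement, so the expectation has little support. The closest guide is compound 2, which also lacks the 4-fluoro-1H-pyrazol-1-yl group and gives 71%.

A small move towards less binding is expected, with no clear departure from the scatter, and the estimated size is a 1.7-fold higher unbound fraction from compound 1 to compound 3 (0.22 log units; within the scatter). For compound 3 the estimated value is 72%, with an expected range from 58% to 84%.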

Compound 3, plasma protein binding: 73.6%
Beside the measured number, compound 3's estimate is 1.1-fold (0.03 log units) (unbound fraction) above it, within the range that was stated.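

In this assay, among these compounds, the pair of compound 1 and compound 3 is the first to isolate a change at this position and gives a 1.6-fold higher unbound fraction from compound 1 to compound 3 (0.20 log units; within the scatter) and so does not separate ethoxy from 4-fluoro-1H-pyrazol-1-yl on this aromatic carbon, meta to a large group and meta to a methyl group. At this position, in the presence of the methyl group, the exchange of a five-membered aromatic ring with 2 hetero atoms for a group with no ring, and of 6 heavy atoms for 3, therefore leaves the plasma protein binding read-out within the scatter. No measurement at hand offers an explanation of this result.

This single step leaves open whether any replacement on this aromatic carbon can move the read-out beyond the scatter, as a basic amine or a carboxylic acid in that place would show. It also leaves open whether a longer chain on the oxygen keeps the read-out within the scatter of compound 3 when the methyl group stays in place.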